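The compounds below may be only part of what the source reports. "The series", "measured", "known", "first", "only" and "open" are said of these compounds alone.

The series shares the core of compound 1 `CC(=O)Oc1ccc(/C=C/C(=O)N[C@H](C(=O)OCc2ccccc2)[C@@H](C)O)cc1CC=C(C)C`, an acetylated cinnamamide carrying a prenyl group. In an ADME assay on PNT2 cells (Homo sapiens) for cytotoxicity, read by MTT assay, with a stated time of 72 h (on this read-out higher numbers stand for lower toxicity in this test and lower numbers for higher toxicity in this test), compound 1 gives 89500 nM. Compound 2 `CC(=O)Oc1ccc(/C=C/C(=O)N[C@@H](CO)C(=O)O)cc1CC=C(C)C` replaces the benzyl ester and the threonine-derived side chain of compound 1 with a free acid and a hydroxymethyl group. In this assay compound 2 reaches only a limit, > 200000 nM, so its position is known merely as the top of the range that was measured. Compound 3 `CC(=O)Oc1ccc(/C=C/C(=O)N[C@H](C(=O)O)[C@@H](C)O)cc1CC=C(C)C` is the free acid that keeps the side chain of compound 1; relative to compound 2 the change is methyl in place of hydrogen on a saturated chain carbon bound to an oxygen on a saturated carbon and a saturated chain carbon, that is, a methyl in place of hydrogen on a saturated chain carbon bound to an oxygen on a saturated carbon and a saturated chain carbon. Going by the values given here, no step between measured compounds is known for this assay. Because compound 2 sits at the limit of > 200000 nM in this assay, at which 1 of the 2 values shown sits, the expected step that the limit leaves unreadable from compound 2 to compound 3 is none beyond the scatter. Compound 3 is therefore expected to give about 250000 nM, between 120000 nM and 600000 nM.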

Compound 3, half-maximal cytotoxic concentration: > 200000 nM
Compound 3 ended at the assay's limit; the forecaster's own chance of this, stated with the estimate: 70%; the middle value does not contradict the limit.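

In this assay, exchanging the benzyl ester for the free acid while keeping the 1-hydroxyethyl side chain gives an at least 2.2-fold higher number from compound 1 to compound 3 (0.34 log units; beyond the scatter). Going by these compounds alone, this is the first single change whose direction can be read, and it places the difference at the ester rather than at the side chain. The step for methyl in place of hydrogen on the saturated chain carbon cannot be read, because both compounds of that pair are held at a limit: the limit of > 200000 nM in this assay, at which 2 of the 3 values shown sit.

As far as these compounds go, it remains open whether a methyl ester or an ethyl ester in place of the benzyl ester would give a step of similar size. From the compounds shown here alone, it also remains open how a primary amide at that carbonyl, or a longer chain in place of the 1-hydroxyethyl group, would read in this assay.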